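A few compounds are considered here, and "the series" means these few. Any claim that something is new, unique, unknown or untested is made for them only; others in the source may bear on it.

Measured compounds:
Compound 1 `CC(=O)c1ccc(NC(=O)Nc2cc(C)nc3ccccc23)cc1` — 19000 nM
Compound 2 `Cc1cc(NC(=O)Nc2ccc3[nH]cnc3c2)c2ccccc2n1` — > 25000 nM
Compound 3 `Cc1cc(NC(=O)Nc2cccc(OC(F)(F)F)c2)c2ccccc2n1` — 13000 nM

These three share one core and were tested in an ADME assay on HepG2 cells (Homo sapiens) for cytotoxicity, with a stated time of 72 h; a higher number here means that more compound is needed for the effect, a lower number that less compound is needed. Compound 1 gives the highest of the two numbers, but compound 3 lies within the scatter of it, so no order between them can be claimed. Compound 2 reaches only (the limit of > 25000 nM in this assay, at which 1 of the 3 values shown sits), which is a limit of the measurement and not a number.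

Compound 4 `Cc1cc(NC(=O)Nc2ccc(C(C)(C)C)cc2)c2ccccc2n1` has not yet been measured. It differs from compound 1 in one place: tert-butyl in place of acetyl on an aromatic carbon. Going by the values given here, no measured pair here shows such a change, so the expected step from compound 1 to compound 4 is small, in no clear direction, and not beyond the scatter.

Compound 4 is therefore estimated at 16000 nM, with a range from 6000 nM to 40000 nM. This estimate means an expected step of a 1.2-fold lower number from compound 1 to compound 4 (0.07 log units; within the scatter) that stays within the usual scatter.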

Compound 4, half-maximal effective concentration: 17000 nM
Beside the measured number, compound 4's estimate is 1.1-fold (0.03 log units) below it; low and high end bracket the measured number.
By their numbers in this assay, from the lowest: compounds 3, 4 and 1 (each within the scatter of the next). At a limit, above all of these: compound 2.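

At this place, on a six-membered aromatic ring of carbon only and para to a large group, tert-butyl in place of acetyl gives a 1.1-fold lower number from compound 1 to compound 4 (0.05 log units; within the scatter) in this assay. The acetyl group carries a hydrogen-bond acceptor and tert-butyl carries none, yet compound 4 stays within the scatter of compound 1. Nothing measured here explains this step.

Going by these compounds, whether an amine or a carboxylic acid at this place would move the number beyond the scatter remains open. A single step also cannot show whether this change would behave the same way elsewhere on the shared core.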